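The compounds below may be only part of what the source reports. "The series", "measured", "known", "first", "only" and "open" are said of these compounds alone.

Measured compounds:
compound 1, `O=C(NC1CC1)c1ccc(-c2cnn3c(NCC4CCOCC4)nc(NC4CCCC4)nc23)cc1`; in a functional assay on OVCAR-3 cells (Homo sapiens) for antiproliferative activity (a higher number here means a weaker inhibitor of growth, a lower number a stronger inhibitor of growth), compound 1 gives 1700 nM
compound 2, `Cc1cc(-c2cnn3c(NCC4CCOCC4)nc(Nc4ccccc4)nc23)ccc1C(=O)NC1CC1`; in this assay compound 2 gives 1700 nM

Compound 2 stands level with compound 1 at the digits shown; the two values lie within the scatter of each other, so nothing can be said about an order between them. Among the measured compounds shown here, compound 1 and compound 2 differ in more than one place and no single step between them is on record, so the two values show only that the shared core tolerates either amine at that position without a visible change in growth inhibition.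

Compound 3, `Cc1cc(-c2cnn3c(NCC4CCOCC4)nc(Nc4ccccc4F)nc23)ccc1C(=O)NC1CC1`, has not yet been measured in this assay. It differs from compound 2 in one place: fluoro in place of hydrogen on an aromatic carbon. For the measured compounds named here, no measured pair carries this change, so there is no step to set its size from. Going by the values given here, the only anchor is that compound 2 gives 1700 nM. Without a reference pair the working expectation is a step of no more than the scatter, in either direction, the estimated step being a 1.1-fold lower number from compound 2 to compound 3 (0.05 log units; within the scatter). Compound 3 is accordingly expected to give about 1500 nM, within a range of 600 nM to 4000 nM; the range is kept wide to allow for the absence of a precedent.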

Compound 3, concentration for 50% growth inhibition: 190 nM
The estimate for compound 3 lay 7.9-fold (0.90 log units) above the measured number, outside the stated range (below it).
By their numbers in this assay, from the lowest: compound 3; then compounds 1 and 2 (each within the scatter of the next).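

In this assay the change from anilino to (2-fluorophenyl)amino gives an 8.9-fold lower number from compound 2 to compound 3 (0.95 log units; beyond the scatter), so this aromatic ring responds to a single fluoro group placed on a carbon ortho to a large group. The earlier pair differed in more than one place and gave no size for any change at this amine, whereas this pair differs in one place and gives a direct measure of that size. Nothing on hand bears on the origin of this step.

On these data alone, it remains open whether the step is particular to fluoro or would also appear with chloro, methyl or methoxy at the same place, and whether moving the fluoro elsewhere on the phenyl ring or adding a second fluoro would keep, enlarge or lose it. Also open, as far as these compounds go, is whether the same step would appear with other parts of the molecule changed, for example with hydrogen in place of the methyl group on the ring that carries the cyclopropyl amide.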